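This account rests on a few compounds, and the source may have more. Where it says the series, first, only, none or still open, it means among the compounds named here.

Measured compounds: compound 1 `COc1cc(N(C)CCN(C)C)c(NC(=O)/C=C\C(C)C)cc1Nc1ncc(C#N)c(-c2cn(C)c3ccccc23)n1` with 1810 nM in a functional assay on HepG2 cells (Homo sapiens) for antiproliferative activity, read by MTT assay, with a stated time of 72 h; on this read-out higher numbers stand for weaker inhibition and lower numbers for stronger inhibition; compound 2 `C=CC(=O)Nc1cc(Nc2nccc(-c3cn(C)c4ccc(F)cc34)n2)c(OC)cc1N(C)CCN(C)C` with 429 nM; compound 3 `C=CC(=O)Nc1cc(Nc2ncc(C#N)c(-c3cn(C)c4ccc(F)cc34)n2)c(OC)cc1N(C)CCN(C)C` with 17500 nM.

Compound 3 stands at the highest number of the three, weakest on this read-out; its nearest neighbour is compound 1 and the furthest is compound 2. Among the measured compounds shown here, the single step between compounds that differ in one place, a 41-fold higher number from compound 2 to compound 3 (1.61 log units; beyond the scatter), concerns the cyano group on the shared core and not the amide side chain, so it does not bear directly on the change at hand.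

Compound 4 `COc1cc(N(C)CCN(C)C)c(NC(=O)/C=C\C(C)C)cc1Nc1ncc(C#N)c(-c2cn(C)c3ccc(F)cc23)n1` arises from compound 3 by 3-methylbut-1-en-1-yl in place of vinyl on a carbonyl carbon. For the measured compounds named here, no measured pair isolates this change. Compound 1 carries the same 3-methylbut-1-en-1-yl group together with the cyano group and gives a markedly lower number than compound 3, but the two also differ in the fluorine, so only a loose reading is possible. Compound 4 is therefore expected to sit somewhat below compound 3, a step of a 4.4-fold lower number from compound 3 to compound 4 (0.64 log units; beyond the scatter), with wide uncertainty. The estimate for compound 4 in this assay is 4000 nM, between 1200 nM and 14000 nM.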

Compound 4, half-maximal inhibitory concentration: 2840 nM
For compound 4 the middle estimate is 1.4-fold (0.15 log units) above the measured one; measured number inside the range.
By their numbers in this assay, from the lowest: compound 2; then compounds 1 and 4 (each within the scatter of the next); then compound 3.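

In this assay, the change finally stands alone in one measured pair, giving a 6.2-fold lower number from compound 3 to compound 4 (0.79 log units; beyond the scatter) with the rest of the structure held fixed, so on this cyano-bearing core the larger 3-methylbut-1-en-1-yl group on the carbonyl carbon gives a lower number than vinyl. With that group in place, adding the fluorine gives a 1.6-fold higher number from compound 1 to compound 4 (0.20 log units; within the scatter) and so shows no difference that can be told from the scatter. Nothing in the data at hand explains either step.

Going by these compounds, whether the side-chain step holds on the core of compound 2, which carries hydrogen where compound 3 carries cyano, remains open. So does how a saturated propyl chain or a dimethylamino-bearing chain on the carbonyl carbon would read.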